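The compounds below may be only part of what the source reports. "The series", "measured", "known", "first", "only" and "open" are said of these compounds alone.

Working notes on the series in a physicochemical assay for lipophilicity, using the shake flask method, at pH 7.4; a higher number here means a more lipophilic compound, a lower number a more polar compound. Compound 3 (`CC(=O)N1CCN([C@H]2CC[C@H](Nc3ncnn4ccc(C5CCOCC5)c34)CC2)CC1`) stands highest of the three measured compounds at 1.6, while compound 1 (`CN(C)[C@H]1CC[C@H](Nc2ncnn3ccc([C@H]4CC[C@@H](C(N)=O)CC4)c23)CC1`) gives 0.1 and compound 2 (`Cc1ccn2ncnc(N[C@H]3CC[C@H](N(C)C)CC3)c12`) gives 0.2.

Compound 4 (`CN(C)[C@H]1CC[C@H](Nc2ncnn3ccc(C4CCOCC4)c23)CC1`) differs from compound 3 in one place: dimethylamino in place of 4-acetylpiperazin-1-yl on a saturated ring carbon.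

Going by the values given here, no measured step makes this exchange directly. Among the compounds with values here, the only measured step, a number 0.10 log units higher from compound 1 to compound 2 (within the scatter), concerns a change on an aromatic carbon, not this one. It does show that two compounds with dimethylamino on the saturated ring carbon sit close together despite that change, although the group compound 4 carries on the aromatic carbon appears in neither of them. Compound 4 is therefore expected to fall towards compound 2 at 0.2, but perhaps not all the way. A decrease beyond the scatter is expected, with the estimated step being a number 1.10 log units lower from compound 3 to compound 4 (beyond the scatter). For compound 4 the estimated value is 0.5, with an expected range of 0 to 1.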

Compound 4, distribution coefficient: 0.5
The estimate for compound 4 equals the measured number at the digits printed; the measured number falls inside the stated range.
By their numbers in this assay, from the lowest: compounds 1, 2 and 4 (each within the scatter of the next, the first and the last beyond it); then compound 3.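

In this assay, going by these compounds alone, the exchange on the saturated ring carbon now has a direct measure: dimethylamino in place of 4-acetylpiperazin-1-yl gives a number 1.10 log units lower from compound 3 to compound 4 (beyond the scatter), the largest step so far. With dimethylamino held in that place, oxan-4-yl in place of methyl on the aromatic carbon gives a number 0.30 log units higher from compound 2 to compound 4 (within the scatter), and oxan-4-yl in place of 4-carbamoylcyclohexyl gives a number 0.40 log units higher from compound 1 to compound 4 (beyond the scatter), both smaller in size than the exchange on the saturated ring carbon. No evidence is at hand on why these steps take the sizes they do.

Within the data shown here, the single exchange cannot separate the piperazine ring from its acetyl group, so a piperazine without the acetyl group would be the telling comparison. On these data alone, whether a carboxylic acid or a longer amine chain on the saturated ring carbon would fall nearer compound 3 or compound 4 also stays open.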